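From Phenoxy to Methoxy: a Smaller Group on Compound 2

This account rests on a few compounds, and the source may have more. Where it says the series, first, only, none or still open, it means among the compounds named here.

Compound 1 `COc1ccc([C@@H]2C/C(=N/OCc3cn(-c4ccccc4CO)nn3)c3cc(CC=C(C)C)c(OC)cc3O2)cc1`: 100%
Compound 2 `COc1cc2c(cc1CC=C(C)C)C(=O)C[C@@H](c1ccc(Oc3ccccc3)cc1)O2`: 53%
Compound 3 `C#CCO/N=C1/C[C@@H](c2ccc(OC)cc2)Oc2cc(OC)c(CC=C(C)C)cc21`: 41%

Three compounds were tested in a functional assay on PC-3 cells (Homo sapiens) for inhibition, read by sulforhodamine B assay, with a stated time of 48 h, tested at 50 uM; a higher number here means more inhibition of growth at the concentration tested, a lower number less inhibition of growth. Compound 1 gives 100%, the highest of the three. Compound 2 gives 53%, the second highest. Compound 3 gives 41%. Compound 2 stands nearest to compound 3, a gap beyond the scatter, and furthest from compound 1.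

Compound 4 `COc1ccc([C@@H]2CC(=O)c3cc(CC=C(C)C)c(OC)cc3O2)cc1` has not yet been measured. It differs from compound 2 in one place: methyl in place of phenyl on an oxygen on an aromatic ring. For the measured compounds named here, no measured pair shows this change, so its size is unknown. Because compound 2 gives only 53%, a moderate downward step is expected, a number 15 percentage points lower from compound 2 to compound 4 (beyond the scatter). Compound 4 is expected to give 38%, with a range from 12% to 65%.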

Compound 4, percent growth inhibition at one concentration: 58%
Compound 4: the middle estimate sits 20 percentage points below what was measured; the range from low to high includes it.
By their numbers in this assay, from the lowest: compound 3; then compounds 2 and 4 (each within the scatter of the next); then compound 1.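

In this assay, the change from phenoxy to methoxy gives a number 5 percentage points higher from compound 2 to compound 4 (within the scatter). For the compounds shown here, this pair is the first to test this position, and it shows that a single methyl can stand in place of the whole phenyl on this oxygen with no difference beyond the scatter. Nothing available explains why the two compounds read alike. The compounds shown leave open whether a longer chain such as butyl, or a benzyl group, on this oxygen would also read alike. They also leave open what a free hydroxyl or an amine here would give.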